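Chain length at the aromatic nitrogen: compounds 1 to 4

The source may hold more compounds than are shown below. What is called first, only, known or untested is meant among the compounds shown, and "the series" means these compounds.

Measured so far in an in vitro functional assay on cells (Fibroblast) for agonist activity at Alpha-1B adrenergic receptor (Homo sapiens); on this read-out higher numbers stand for an effect only at larger amounts of compound and lower numbers for an effect already at smaller amounts:
compound 1 `CC(C)n1ncnc1-c1ccccc1NCC1=NCCN1`, < 100000 nM, a limit of the assay and not a number
compound 2 `Cn1nccc1-c1ccccc1NCC1=NCCN1`, < 100000 nM, a limit of the assay and not a number
compound 3 `CCn1nccc1-c1ccccc1NCC1=NCCN1`, < 100000 nM, a limit of the assay and not a number

Compound 3 therefore stands only as a limit in this assay, with no number of its own. Going by the values given here, all three values shown sit at the same limit (the limit of < 100000 nM in this assay, at which 3 of the 3 values shown sit), so the one step that can be drawn between measured compounds, a step that the two limits leave unreadable from compound 2 to compound 3, cannot be read in size or direction.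

Compound 4 `CC(C)n1nccc1-c1ccccc1NCC1=NCCN1` differs from compound 3 by methyl in place of hydrogen on a saturated chain carbon bound to an aromatic nitrogen and a saturated chain carbon. Among the compounds with values here, the one measured step bearing on the same kind of change, a step that the two limits leave unreadable from compound 2 to compound 3, gives no readable size, so no direction beyond the scatter can be derived for the change from compound 3 to compound 4. Compound 4 is expected at 10000 nM, with a range from 1000 nM to 100000 nM, and a high chance that only the same limit is reported again. The expected step is accordingly a step that the limit leaves unreadable from compound 3 to compound 4, which is not a step beyond the scatter.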

Compound 4, half-maximal effective concentration: < 100000 nM
Compound 4 ended at the assay's limit; the forecaster's own chance of this, stated with the estimate: 70%; the middle value is on the limit's open side.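

In this assay compound 4 gives < 100000 nM as a limit of the assay and not a number. The steps from compound 2 and compound 3 to compound 4 cannot be read in size or direction, as all values shown share one limit: the limit of < 100000 nM in this assay, at which 4 of the 4 values shown sit.

Compound 2, compound 3 and compound 4 leave open whether methyl, ethyl or isopropyl on the aromatic nitrogen makes any difference to the read-out.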